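Working notes on compound 1 and its sulfanyl analogue

The compounds below may be only part of what the source reports. "The series", "measured", "known", "first", "only" and "open" are said of these compounds alone.

Three compounds of the series have numbers in a functional assay on HCT-116 cells (Homo sapiens) for inhibition, read by sulforhodamine B assay, with a stated time of 48 h; a lower number here means a stronger inhibitor of growth, a higher number a weaker inhibitor of growth. Compound 1 `Nc1cc(N)c2nc(-c3ccccc3)c(Oc3ccc(F)cc3)nc2c1` gives 81300 nM and stands highest of the three. The nearest number belongs to compound 3 `COc1ccc(CNc2nc3cc(N)cc(N)c3nc2-c2ccccc2)cc1`, which in this assay gives 27500 nM; the furthest belongs to compound 2 `COc1cc(CNc2nc3cc(N)cc(N)c3nc2-c2ccccc2)cc(OC)c1OC`, which in this assay gives 19100 nM. For the measured compounds named here, both gaps lie beyond the usual scatter, so compound 1 is the weakest growth inhibitor among the three measured so far.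

Compound 4 `COc1ccc(Sc2nc3cc(N)cc(N)c3nc2-c2ccccc2)cc1` has not yet been measured. It differs from compound 1 in one place: (4-methoxyphenyl)sulfanyl in place of 4-fluorophenoxy on an aromatic carbon. Going by the values given here, no pair of measured compounds covers this exchange, so the expectation rests on the set as a whole. Compounds 2 and 3 carry other groups on the same aromatic carbon and both give lower numbers than compound 1, which points towards a moderate downward step, in the direction of stronger growth inhibition. The expected step is a 2.3-fold lower number from compound 1 to compound 4 (0.37 log units; beyond the scatter), kept modest because compound 3 gives 27500 nM and nothing in the set suggests a larger move. Compound 4 is therefore expected to give 35000 nM in this assay, with a plausible range from 10000 nM to 100000 nM.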

Compound 4, concentration for total growth inhibition: < 100000 nM
Compound 4 was reported as a limit; the forecaster's own chance of this, stated with the estimate: 5%; the middle value does not contradict the limit.
By their numbers in this assay, from the lowest: compounds 2 and 3 (each within the scatter of the next); then compound 1.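

In this assay compound 4 gives < 100000 nM, which is a limit of the assay and not a number. No step from compound 1 to compound 4 can be read from it: the limit of < 100000 nM in this assay, at which 1 of the 4 values shown sits.

The compounds shown leave open whether (4-methoxyphenyl)sulfanyl in place of 4-fluorophenoxy on an aromatic carbon changes the number in this assay, and in which direction.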